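Fluoro to nitro on two related ketone cores

This account rests on a few compounds, and the source may have more. Where it says the series, first, only, none or still open, it means among the compounds named here.

Of the compounds shown here, three have been measured. Compound 1 `O=C1/C(=C/c2ccccc2F)CCc2ccccc21` gives 22800 nM in a functional assay on L1210 cells (Mus musculus) for inhibition; on this read-out higher numbers stand for weaker inhibition and lower numbers for stronger inhibition. Compound 3 `O=C1/C(=C/c2ccccc2[N+](=O)[O-])CCc2ccccc21` differs from it by nitro in place of fluoro on an aromatic carbon, and that step, a 2.1-fold lower number from compound 1 to compound 3 (0.32 log units; beyond the scatter), is modest but beyond the scatter. In this assay compound 3 gives 10800 nM. Compound 2 `O=C1/C(=C/c2ccccc2F)Cc2ccccc21` has a different core; how the two cores differ is not broken down here. In this assay compound 2 gives 150000 nM, the highest of the three numbers. Compound 4 `O=C1/C(=C/c2ccccc2[N+](=O)[O-])Cc2ccccc21` has not been measured; it differs from compound 2 by nitro in place of fluoro on an aromatic carbon, the same change in the same place as before. The expected step of a 2.1-fold lower number from compound 2 to compound 4 (0.33 log units; beyond the scatter) rests on the earlier step of a 2.1-fold lower number from compound 1 to compound 3 (0.32 log units; beyond the scatter) seen on the core of compound 1. Compound 4 is therefore estimated at 70000 nM, with a plausible range from 30000 nM to 160000 nM.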

Compound 4, half-maximal inhibitory concentration: 7610 nM
For compound 4 the middle estimate is 9.2-fold (0.96 log units) above the measured one; measured number below the stated range.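

In this assay, nitro in place of fluoro on an aromatic carbon gives a 20-fold lower number from compound 2 to compound 4 (1.29 log units; beyond the scatter), a large step. Within the data shown here, the number falls on both cores, but the size of the fall does not carry over from one core to the other: the same change on two cores in this assay, a 2.1-fold lower number (0.32 log units; beyond the scatter) from compound 1 to compound 3 and a 20-fold lower number (1.29 log units; beyond the scatter) from compound 2 to compound 4, 9.3-fold (0.97 log units) apart, beyond the scatter of two such steps Two pairs show only that a step measured on one core can be a poor guide to its size on the other; they do not show why the steps differ or which size a further core would give.

The compounds shown leave open how other groups on this aromatic carbon, such as chloro, methoxy or an amine, would behave. As far as these compounds go, whether such groups would also give steps of different size on the two cores remains unknown.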